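A few compounds are considered here, and "the series" means these few. Any claim that something is new, unique, unknown or untested is made for them only; others in the source may bear on it.

Measured in a functional assay on ACHN cells (Homo sapiens) for inhibition, read by sulforhodamine B assay, with a stated time of 48 h; on this read-out lower numbers stand for stronger inhibition of growth and higher numbers for weaker inhibition of growth:
- compound 1 `O=C(Nc1cccc(-n2cc(-c3ccncc3)c(-c3ccc(Cl)c(O)c3)n2)c1)Nc1cccc(C(F)(F)F)c1`: > 32500 nM, a limit
- compound 2 `COc1cc(-c2nn(-c3cccc(NC(=O)c4cccc(C(F)(F)F)c4)c3)cc2-c2ccncc2)ccc1Cl`: > 50000 nM, a limit

Neither compound has a numerical value in this assay, so the series has no measured number to work from. Compound 2, the reference point for the next step, stands at > 50000 nM, which is a limit. Compound 1 also stands at a limit, > 32500 nM.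

Compound 3 `COc1cc(-c2nn(-c3cccc(NC(=O)c4ccc(Cl)c(C(F)(F)F)c4)c3)cc2-c2ccncc2)ccc1Cl` takes compound 2 and places chloro in place of hydrogen on an aromatic carbon, ortho to a trifluoromethyl group and para to a large group, turning 3-(trifluoromethyl)phenyl into 4-chloro-3-(trifluoromethyl)phenyl: chloro in place of hydrogen on an aromatic carbon.

Among the compounds with values here, no measured step shows what such a change does, so the expectation is loose. A modest move towards stronger growth inhibition is expected, and a result that again reports only a limit is about as likely. The expected step is an at least 1.6-fold lower number from compound 2 to compound 3 (0.22 log units; that floor lies within the scatter), and it is anchored only on the limit of compound 2 at > 50000 nM. The estimate for compound 3 is 30000 nM, with an expected range from 6000 nM to 70000 nM.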

Compound 3, concentration for total growth inhibition: > 32500 nM
Compound 3 ended at the assay's limit (the forecaster's own chance of this, stated with the estimate: 50%); middle value at least 1.0-fold (0.03 log units) from the limit.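

Compound 2 and compound 3 both stand only at limits in this assay, and no step can be read between them. The compounds shown leave open what chloro in place of hydrogen on an aromatic carbon does to the read-out, and whether any compound of this series gives a numerical value in this assay.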